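Swapping Methylsulfanyl for Phenyl: Compound 2 to Compound 4

The source may report more compounds than this note shows. Statements on the series, on what has been measured and on what is new or still open speak of the compounds shown alone.

Compound 1 `FC(F)(F)c1ccc(Nc2ncnc3sc(Nc4c(Cl)cccc4Cl)nc23)cc1Cl` gives 21 nM in a functional assay on HEK293 cells for antagonist activity at transient receptor potential cation channel subfamily V member 1 (Homo sapiens), read by calcium flux; a higher number here means a weaker inhibitor, a lower number a stronger inhibitor.
Compound 2 `CSc1nc(Nc2ccc(C(F)(F)F)c(Cl)c2)c2nc(Nc3c(Cl)cccc3Cl)sc2n1` gives 224 nM in this assay.
Compound 3 `FC(F)(F)c1ccc(Nc2nc(N3CCC3)nc3sc(Nc4c(Cl)cccc4Cl)nc23)cc1` gives 59 nM in this assay.

Compound 2 has the highest number of the three; compound 3 sits below it and compound 1 further below, both gaps beyond the scatter. Compound 4 `FC(F)(F)c1ccc(Nc2nc(-c3ccccc3)nc3sc(Nc4c(Cl)cccc4Cl)nc23)cc1Cl` differs from compound 2 by phenyl in place of methylsulfanyl on an aromatic carbon. Going by the values given here, the only single-change step touching this position, an 11-fold higher number from compound 1 to compound 2 (1.03 log units; beyond the scatter), was large, so a group here can move the number a long way. Among the compounds with values here, compound 3 carries an azetidinyl group at this position with a different aryl ring, and its number is lower than that of compound 2, though no single-change step links them. Within the data shown here, no measured step shows what phenyl does here. Compound 4 is therefore estimated at 150 nM, with a range from 40 nM to 600 nM, which means an expected step of a 1.5-fold lower number from compound 2 to compound 4 (0.17 log units; within the scatter).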

Compound 4, half-maximal inhibitory concentration: 539 nM
For compound 4 the middle estimate is 3.6-fold (0.56 log units) below the measured one, and the stated range covers the measured number.
By their numbers in this assay, from the lowest: compound 1; then compound 3; then compound 2; then compound 4.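

In this assay, phenyl in place of methylsulfanyl gave a 2.4-fold higher number from compound 2 to compound 4 (0.38 log units; beyond the scatter), so a larger aromatic group on this carbon did not bring the number back down. Against hydrogen, phenyl gave a 26-fold higher number from compound 1 to compound 4 (1.41 log units; beyond the scatter), which orders the three groups at this position, from the lowest number: hydrogen, methylsulfanyl, phenyl. Nothing available offers a reason for this order. The compounds shown leave open how a methoxy group or a primary amine on this carbon would compare with hydrogen. They also leave open how azetidinyl, seen in compound 3 with a different aryl ring, would compare on the aryl ring of compound 1.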